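The source may report more compounds than this note shows. Statements on the series, on what has been measured and on what is new or still open speak of the compounds shown alone.

Compound 1 `O=C(CC1c2ccccc2N=C(SCCCCCN2CCCC2)N1c1ccc(-c2ccccc2)cc1)NCc1ccc(F)cc1` is the starting point. In an assay on cells for inhibition of Voltage-dependent T-type calcium channel subunit alpha-1I (Homo sapiens), read by patch clamp, tested at 10 uM (on this read-out higher numbers stand for more inhibition at the one concentration tested (going by the name of the read-out) and lower numbers for less inhibition), compound 1 gives 55.9%. Compound 3 `O=C(CC1c2ccccc2N=C(SCCCCCN2CCCC2)N1c1ccc(-c2ccc(F)cc2)cc1)NCc1ccc(F)cc1` carries one change from it, (fluoro in place of hydrogen on an aromatic carbon), and in this assay compound 3 gives 35.1%, a step of a number 20.8 percentage points lower from compound 1 to compound 3 (beyond the scatter). Compound 2 `CN(C)CCCCCSC1=Nc2ccccc2C(CC(=O)NCc2ccccc2)N1c1ccc(-c2ccccc2)cc1` has a core whose difference from that of compound 1 is not broken down here; in this assay compound 2 gives 85.6%, the highest of the three. Compound 4 `CN(C)CCCCCSC1=Nc2ccccc2C(CC(=O)NCc2ccc(F)cc2)N1c1ccc(-c2ccccc2)cc1` differs from compound 2 by fluoro in place of hydrogen on an aromatic carbon, the same kind of change, although read one bond further out it is benzyl to 4-fluorobenzyl rather than phenyl to 4-fluorophenyl. Because the earlier step was a number 20.8 percentage points lower from compound 1 to compound 3 (beyond the scatter), a step of a number 17.6 percentage points lower from compound 2 to compound 4 (beyond the scatter) is expected here. Compound 4 is therefore estimated at 68%, between 45% and 88%.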

Compound 4, a percentage reported as inhibition, at one concentration (the size of the read-out at that concentration, not a potency): 69.3%
Estimate against measurement, compound 4: 1.3 percentage points below, and the stated range covers the measured number.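

In this assay, for the compounds shown here, the fluoro change lowers the number on a second core, a number 16.3 percentage points lower from compound 2 to compound 4 (beyond the scatter), and the two steps agree in size: the same change on two cores in this assay, a number 20.8 percentage points lower (beyond the scatter) from compound 1 to compound 3 and a number 16.3 percentage points lower (beyond the scatter) from compound 2 to compound 4, 4.5 percentage points apart, within the scatter of two such steps This shows that the change carried over between these two cores, but it rests on only two pairs and does not show that it would carry to other cores, or that the ring bearing the fluoro is irrelevant, since phenyl becomes 4-fluorophenyl in compound 3 and benzyl becomes 4-fluorobenzyl in compound 4. A separate change, dimethylamino in place of pyrrolidin-1-yl, gives a number 13.4 percentage points higher from compound 1 to compound 4 (beyond the scatter), seen on one pair only.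

The compounds shown leave open whether a chloro or a methoxy group in place of the fluoro would lower the number in the same way. They also leave open how a piperidine at the chain end, or a longer chain, would read.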